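Aniline variation on a trifluoromethylpyrimidine series

The source may report more compounds than this note shows. Statements on the series, on what has been measured and on what is new or still open speak of the compounds shown alone.

Compound 1 `CN(c1cccc2c1CN(c1nc(Nc3cccc(Oc4ccccc4)c3)ncc1C(F)(F)F)C2)S(C)(=O)=O` and compound 2 `Cc1cc(Cl)ccc1Nc1ncc(C(F)(F)F)c(N2Cc3cccc(N(C)S(C)(=O)=O)c3C2)n1` share the same core and differ only in the aniline attached to it. In a functional assay on U-87MG ATCC cells for antiproliferative activity against U-87 MG (Homo sapiens), read by spectrophotometry, with a stated time of 2 days (a higher number here means a weaker inhibitor of growth, a lower number a stronger inhibitor of growth), compound 1 gives 19500 nM, and in this assay compound 2 gives 28300 nM. Of the two numbers, compound 1 has the lower one, but the gap to compound 2 lies within the scatter of repeated measurements, so neither compound can be called the stronger inhibitor of growth on this evidence.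

Compound 3 `CN(c1cccc2c1CN(c1nc(Nc3cccc(C(F)(F)F)c3)ncc1C(F)(F)F)C2)S(C)(=O)=O` keeps the core of compound 1 and alters the aniline in one place: trifluoromethyl in place of phenoxy on an aromatic carbon. The new group sits on an aromatic carbon of a six-membered aromatic ring of carbon only, meta to a large group.

For the measured compounds named here, no pair of measured compounds that differ in a single place is available, so there is no reference step for this kind of exchange. Both measured compounds sit in the same weak region of this assay, and the change from compound 1 to compound 3 is expected to move the value by no more than the scatter, in no clear direction. Compound 3 is therefore expected to give about 22000 nM in this assay, within 7000 nM to 70000 nM, which means an expected step of a 1.1-fold higher number from compound 1 to compound 3 (0.05 log units; within the scatter).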

Compound 3, concentration for 50% growth inhibition: > 30000 nM
Compound 3: only a limit was reported (the forecaster's own chance of this, stated with the estimate: 10%); middle value at least 1.3-fold (0.13 log units) away from the limit.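

In this assay compound 3 carries a limit of the assay and not a number: the limit of > 30000 nM in this assay, at which 1 of the 3 values shown sits. Trifluoromethyl in place of phenoxy on this aromatic carbon gives an at least 1.5-fold higher number from compound 1 to compound 3 (0.18 log units; that floor lies within the scatter), and 3-(trifluoromethyl)phenyl in place of 4-chloro-2-methylphenyl on the nitrogen gives an at least 1.0-fold higher number from compound 2 to compound 3 (0.02 log units; that floor lies within the scatter); both are floors inside the scatter, so neither exchange is shown to weaken growth inhibition, although the true steps may be larger. What is new is the direction: the smaller group without a ring gives no sign of stronger growth inhibition at this position, so removing the phenoxy ring does not bring the series out of its weak region.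

On these data alone, how far compound 3 lies past its limit stays open, and with it the true size of both steps. Also open is whether an amine, a carboxylic acid or a longer chain on this aromatic carbon would give a clearly lower number than the three compounds shown.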